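Morpholinyl amide to methylamide on the pyridinyl-acrylamide series

This account rests on a few compounds, and the source may have more. Where it says the series, first, only, none or still open, it means among the compounds named here.

Three compounds from this set were measured in an assay on a protein complex for inhibition of CDK8/Cyclin C (Homo sapiens), with a stated time of 1 h, tested at 10 uM; on this read-out higher numbers stand for more inhibition at the one concentration tested (going by the name of the read-out) and lower numbers for less inhibition. Compound 1 `CNC(=O)/C=C/c1ccncc1-c1ccc2c(cnn2C)c1` gives 98% in this assay, compound 2 `Cn1ncc2ccc(-c3cnccc3/C=C/C(=O)N3CCOCC3)cc21` gives 89%, and compound 3 `O=C(/C=C/c1ccncc1-c1ccc2ccccc2c1)N1CCOCC1` gives 99%. On these numbers compound 2 stands lowest of the three, yet its gap to compound 1 and its gap to compound 3 both lie within the usual scatter of repeated measurements, so the three compounds cannot be told apart on this read-out.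

Compound 4 `CNC(=O)/C=C/c1ccncc1-c1ccc2cnn(C)c2c1` has not been measured. It differs from compound 2 in one place: methylamino in place of morpholin-4-yl on a carbonyl carbon. Cut one bond further out, the same change reads (morpholin-4-yl)carbonyl to methylcarbamoyl. Within the data shown here, no measured pair in this set differs by exactly this change, so nothing here tells how large a step it brings.

The nearest guide is compound 1, which carries the methylcarbamoyl group and gives 98% in this assay. Because compound 1 gives 98% and compound 2 gives 89%, a step of a number 6 percentage points higher from compound 2 to compound 4 (within the scatter) is expected, one that does not exceed the scatter. Compound 4 is therefore estimated to reach 95% in this assay, somewhere between 85% and 99%.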

Compound 4, a percentage reported as inhibition, at one concentration (the size of the read-out at that concentration, not a potency): 99%
Beside the measured number, compound 4's estimate is 4 percentage points below it, within the range that was stated.
By their numbers in this assay, from the lowest: compounds 2, 1, 3 and 4 (each within the scatter of the next).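

Among these compounds, the new pair gives the first direct reading of this change: in this assay, methylamino in place of morpholin-4-yl on a carbonyl carbon brings a number 10 percentage points higher from compound 2 to compound 4 (within the scatter). The earlier compounds shown here carried one group or the other on different cores, whereas this pair shows that, on the shared core of compound 2 and compound 4, the six-membered non-aromatic ring can leave and the much smaller methylamino can enter without a step that stands clear of the scatter, even though the count of hydrogen-bond donors and acceptors changes with it. Nothing available explains this outcome, and none of the data shown bear on it.

The compounds shown leave open whether a larger group on the amide nitrogen, such as a longer alkyl chain, or a replacement of the whole amide by a carboxylic acid or a nitrile, would also keep the read-out at this place. They also leave open how far compound 2 and compound 4 differ in potency, as a percentage at one concentration does not give one.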